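Trimming an alkyl group on a weak inhibitor

The compounds below may be only part of what the source reports. "The series", "measured", "known", "first", "only" and "open" are said of these compounds alone.

Compound 1 `CC(C)(C)NC(=O)N1CC1C#N` gives the higher of the two numbers available. In a functional assay on A549 cells (Homo sapiens) for inhibition (on this read-out higher numbers stand for weaker inhibition and lower numbers for stronger inhibition), compound 1 gives 180000 nM, while compound 2 `CCOC(=O)c1ccc(NC(=O)N2CC2C#N)cc1` gives 2900 nM, a gap that lies well beyond the scatter. Compound 3 `CCNC(=O)N1CC1C#N` differs from compound 1 by ethyl in place of tert-butyl on an amide-type nitrogen. For the measured compounds named here, no measured pair shows what this swap does, so no change beyond the scatter is expected: the step from compound 1 to compound 3 in this assay is estimated as a 1.4-fold higher number from compound 1 to compound 3 (0.14 log units; within the scatter). Compound 3 is therefore expected near 250000 nM, within a range from 60000 nM to 1000000 nM.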

Compound 3, half-maximal inhibitory concentration: 18000 nM
Compound 3: the middle estimate sits 14-fold (1.14 log units) above what was measured; the whole stated range lies above it.
By their numbers in this assay, from the lowest: compound 2; then compound 3; then compound 1.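

On the amide-type nitrogen, ethyl in place of tert-butyl gives a 10-fold lower number from compound 1 to compound 3 (1.00 log units; beyond the scatter) in this assay, so the alkyl group at this position clearly matters for inhibition. Of these two groups, ethyl goes with the stronger inhibition, even though the rest of the molecule stays the same. Nothing available here explains why this swap has such an effect.

From the compounds shown here alone, whether a methyl group on the same nitrogen would lower the number further remains open. So does the effect of a longer chain, or of a chain ending in an amine.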